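The source may hold more compounds than are shown below. What is called first, only, known or untested is meant among the compounds shown, and "the series" means these compounds.

Working notes on the aminoindane series. Within the data shown here, compound 1 `C#CCNC1CCc2c(NCc3cccc(Br)c3)cccc21` is the only member with a number: in an ADME assay on cells for inhibition of Amine oxidase [flavin-containing] A (Homo sapiens), read by fluorescence and Amplex Red, with stated times of 30 min and 15 min (on this read-out higher numbers stand for weaker inhibition and lower numbers for stronger inhibition), compound 1 gives 94300 nM. Compound 2 `C#CCNC1CCc2c(SCc3ccc(C(C)(C)C)cc3)cccc21` carries no result, recorded as "not determined" (no result reported) in this assay. Compound 3 `C#CCNC1CCc2c(OCCc3cc(NC(=O)c4ccccc4)ccc3Cl)cccc21` likewise stands without a single number; in this assay compound 3 is recorded as "not determined" (no result reported), and it is one of two entries in the set with no value to place on the scale. Compound 4 `C#CCNC1CCc2c(OCCc3cc(NC(=O)CO)ccc3Cl)cccc21` differs from compound 3 in one place: hydroxymethyl in place of phenyl on a carbonyl carbon. Among the measured compounds shown here, no step between measured compounds exists in this set, so nothing in the numbers says how far or in which direction this change should move the read-out in this assay; the only anchor is the weak result of compound 1, and the expectation is that compound 4 will also sit in the weak range, with no direction claimed beyond the scatter. On that basis compound 4 is estimated at 60000 nM in this assay, expected between 6000 nM and 600000 nM, with a real chance that only a limit is reported.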

Compound 4, half-maximal inhibitory concentration: 252000 nM
Compound 4: middle estimate off by 4.2-fold (0.62 log units), on the low side; low and high end bracket the measured number.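

In this assay compound 3 has no single number, so no step can be read from compound 3 to compound 4. On these data alone, what hydroxymethyl in place of phenyl on a carbonyl carbon does to the read-out stays open. No evidence bears on the result.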